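This account rests on a few compounds, and the source may have more. Where it says the series, first, only, none or still open, it means among the compounds named here.

Measured so far:
Compound 1 `O=c1cc(CNCc2ccccc2)oc2ccc(O)c(O)c12` — > 100000 nM
Compound 2 `Cc1ccccc1CNCc1cc(=O)c2c(O)c(O)ccc2o1` — 52200 nM
Compound 3 `O=c1cc(CNCc2cccc(I)c2)oc2ccc(O)c(O)c12` — > 100000 nM

In an ADME assay on Huh-7 cells (Homo sapiens) for cytotoxicity (on this read-out higher numbers stand for lower toxicity in this test and lower numbers for higher toxicity in this test), compound 1 gives > 100000 nM, a limit of the assay and not a number. Compound 3 likewise gives > 100000 nM, again a limit. Compound 2 gives 52200 nM. Compound 4 `Cc1cccc(CNCc2cc(=O)c3c(O)c(O)ccc3o2)c1` is not yet measured; against compound 1 it shows (methyl in place of hydrogen on an aromatic carbon). The nearest measured step is an at least 1.9-fold lower number from compound 1 to compound 2 (0.28 log units; that floor lies within the scatter), also methyl in place of hydrogen on an aromatic carbon. The step of an at least 1.9-fold higher number from compound 2 to compound 3 (0.28 log units; that floor lies within the scatter) runs back up, and a step that the two limits leave unreadable from compound 1 to compound 3 cannot be read, since (the limit of > 100000 nM in this assay, at which 2 of the 3 values shown sit). Nothing measured here separates one methyl placement from the other. For compound 4 in this assay a value near 80000 nM is expected, between 35000 nM and 200000 nM, an expected step of an at least 1.2-fold lower number from compound 1 to compound 4 (0.09 log units; that floor lies within the scatter) that may well end at the limit again.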

Compound 4, half-maximal cytotoxic concentration: > 100000 nM
Compound 4: no number, only a limit (the forecaster's own chance of this, stated with the estimate: 50%); at least 1.2-fold (0.09 log units) between middle value and limit.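

In this assay compound 4, with its 3-methylphenyl, gives a limit and not a number, so a methyl on this ring does not by itself produce a readable value; of the two placements, only the 2-methylphenyl of compound 2 does. Among these compounds, the one readable step is an at least 1.9-fold higher number from compound 2 to compound 4 (0.28 log units; that floor lies within the scatter), so the two placements are not yet separated beyond the scatter. The steps to compound 4 from compound 1 and compound 3 cannot be read: the limit of > 100000 nM in this assay, at which 3 of the 4 values shown sit.

Still open, going by these compounds, is how far past the limit compound 1, compound 3 and compound 4 lie. Also open, on these data alone, is whether a longer chain or a carboxylic acid in place of this methyl would give a readable value.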